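The compounds below may be only part of what the source reports. "The series", "measured", "known", "first", "only" and "open" are said of these compounds alone.

Measured so far:
compound 1 `C=CCOc1ccc2c(NCCCN(C)C)ccnc2c1` gives 3560 nM
compound 2 `CCOc1ccc2c(Cl)ccnc2c1` gives 3870 nM
compound 3 `CCOc1ccc2c(NCCN(C)C)ccnc2c1` gives 3650 nM

All three numbers come from a functional assay on RKO cells (Homo sapiens) for cytotoxicity, read by MTT assay, with a stated time of 48 h; a higher number here means a weaker inhibitor, a lower number a stronger inhibitor. On the raw numbers compound 2 has the highest of the three, but this is not a real separation: the step from it to compound 3 is a 1.1-fold lower number from compound 2 to compound 3 (0.03 log units; within the scatter), and its gap to compound 1 is also within the scatter, so the three compounds cannot be told apart by these measurements.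

Compound 4 `C=CCOc1ccc2c(Cl)ccnc2c1` keeps the chloro of compound 2 and changes only the side chain on the oxygen: vinyl in place of methyl on a saturated chain carbon bound to an oxygen on an aromatic ring. For the measured compounds named here, no measured step changes this part of the molecule on its own. Compound 1 carries the allyloxy group and compound 3 the ethoxy group, but they also differ in their amino side chains, so their two numbers can only be noted as lying close to each other, not read as a step. Going by the values given here, the one measured step, from compound 2 to compound 3, replaced the chloro and stayed within the scatter, and offers no reason to expect movement here either. The expected step is therefore a 1.0-fold lower number from compound 2 to compound 4 (0.01 log units; within the scatter), a change no larger than the scatter. Compound 4 is accordingly estimated at 3800 nM, with a likely range from 1900 nM to 7600 nM.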

Compound 4, half-maximal inhibitory concentration: 2460 nM
The estimate for compound 4 lay 1.5-fold (0.19 log units) above the measured number, within the range that was stated.
By their numbers in this assay, from the lowest: compounds 4, 1, 3 and 2 (each within the scatter of the next).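

For the compounds shown here, this is the first step that changes only the group on the oxygen: ethoxy becomes allyloxy, or ethyl becomes allyl, while the chloro stays in place. In this assay, that change gives a step that does not separate the two compounds (a 1.6-fold lower number from compound 2 to compound 4 (0.20 log units; within the scatter)), so the extra carbon and the double bond outside aromatic rings produce no readable change here. The allyloxy pair adds a second comparison on the other side of the molecule, where the step also stays within the scatter (a 1.4-fold lower number from compound 1 to compound 4 (0.16 log units; within the scatter)), and no explanation can be offered for either step, as nothing measured beyond these numbers bears on them.

These four compounds therefore show only that ethoxy and allyloxy cannot be told apart, with chloro on the core, and that chloro and the (3-(dimethylamino)propyl)amino group cannot be told apart, with allyloxy on the core. Open, on these data alone, is whether a group of a different kind on the oxygen, such as a longer chain like hexyl or a chain ending in a carboxylic acid, would move the number beyond the scatter.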